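The source may report more compounds than this note shows. Statements on the series, on what has been measured and on what is new or still open speak of the compounds shown alone.

Measured compounds in a functional assay on HL-60 cells (Homo sapiens) for antiproliferative activity, read by MTT assay, with a stated time of 72 h; on this read-out higher numbers stand for weaker inhibition and lower numbers for stronger inhibition: compound 1 `CCC(=O)N(C)c1ccc2[nH]c(-c3n[nH]c4ccccc34)cc2n1` gives 6130 nM; compound 2 `COc1cccc(C(=O)N(C)c2ccc3[nH]c(-c4n[nH]c5ccccc45)cc3n2)c1` gives 1420 nM; compound 3 `CN(c1ccc2[nH]c(-c3n[nH]c4ccccc34)cc2n1)S(=O)(=O)c1ccc(Cl)cc1` gives 770 nM.

Compound 3 gives the lowest number of the three, but its gap to compound 2 is within the scatter, so no order between those two is claimed. Compound 4 `COc1ccc(S(=O)(=O)N(C)c2ccc3[nH]c(-c4n[nH]c5ccccc45)cc3n2)c(OC)c1` differs from compound 3 by 2,4-dimethoxyphenyl in place of 4-chlorophenyl on a sulfonyl sulfur. Going by the values given here, no measured step swaps one aryl group for another on the sulfonyl sulfur; the nearest precedents are an 8.0-fold lower number from compound 1 to compound 3 (0.90 log units; beyond the scatter) and a 1.8-fold lower number from compound 2 to compound 3 (0.27 log units; within the scatter), the latter within the scatter. A methoxy-bearing aryl entered once, in a 4.3-fold lower number from compound 1 to compound 2 (0.64 log units; beyond the scatter), but on a carbonyl carbon. The expected step is therefore small, a 1.2-fold higher number from compound 3 to compound 4 (0.07 log units; within the scatter), most likely within the scatter. Compound 4 is estimated at 900 nM, range 350 nM to 2500 nM.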

Compound 4, half-maximal inhibitory concentration: 5180 nM
Beside the measured number, compound 4's estimate is 5.8-fold (0.76 log units) below it, outside the stated range (above it).
By their numbers in this assay, from the lowest: compounds 3 and 2 (each within the scatter of the next); then compounds 4 and 1 (each within the scatter of the next).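

The aryl group on the sulfonyl sulfur matters in this assay, since 2,4-dimethoxyphenyl in place of 4-chlorophenyl gives a step beyond the scatter (a 6.7-fold higher number from compound 3 to compound 4 (0.83 log units; beyond the scatter)). A sulfonyl group on the sulfonamide nitrogen therefore does not by itself secure the low number of compound 3, and the aryl group it carries must be counted as well. Nothing at hand accounts for this step.

Because the chlorine leaves and both methoxy groups enter in one change, their separate contributions remain unresolved. From the compounds shown here alone, how a plain phenyl, a single methoxy or an aminomethyl group on that aryl ring would read also remains open.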